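The source may hold more compounds than are shown below. What is called first, only, known or untested is meant among the compounds shown, and "the series" means these compounds.

In a functional assay on HO8910 cells (Homo sapiens) for inhibition, read by MTT assay, with a stated time of 24 h, tested at 100 ug/mL (on this read-out higher numbers stand for more inhibition of growth at the one concentration tested and lower numbers for less inhibition of growth), compound 1 (`O=C(CCCCC1CCSS1)Nc1ccc(Br)cn1`) gives 32.1% and compound 2 (`O=C(CCCCC(S)CCS)Nc1ccc(Cl)cn1`) gives 71.2% as the higher of the two numbers, with a gap beyond the scatter. Among the measured compounds shown here, no measured pair isolates a single structural change, so this gap is not assigned to any one feature.

Compound 3 (`O=C(CCCCC(S)CCS)Nc1ccc(Br)cn1`) is still unmeasured. Its change from compound 2 is bromo in place of chloro on an aromatic carbon, and the rest of the structure stays the same.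

With no measured halogen exchange available in this assay as a guide, no step beyond the scatter is expected, with only a slight lean downward. Compound 1 also carries bromo and gives 32.1% in these measurements, but that one number does not isolate the halogen, so it serves only to widen the range on the low side.

The estimated change is a number 5.2 percentage points lower from compound 2 to compound 3 (within the scatter) and is expected to stay within the scatter. For compound 3 the estimated value is 66% with an expected range from 48% to 82% in this single-concentration test.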

Compound 3, percent growth inhibition at one concentration: 56.8%
Estimate against measurement, compound 3: 9.2 percentage points above; low and high end bracket the measured number.
By their numbers in this assay, from the lowest: compound 1; then compound 3; then compound 2.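

In this assay, the halogen on the aromatic carbon two atoms from the ring nitrogen now has a direct reading: bromo in place of chloro gives a number 14.4 percentage points lower from compound 2 to compound 3 (beyond the scatter), so with the open-chain sulfur group in place, this position is not indifferent to which of these two halogens it carries. With bromo held constant, the chain end can also be read on its own, and the open group of 5 heavy atoms in place of the five-membered non-aromatic ring with 2 hetero atoms gives a number 24.7 percentage points higher from compound 1 to compound 3 (beyond the scatter), a change in one place that the earlier pair could not isolate. Nothing available explains either step.

It remains open whether the halogen step carries over to the ring form of the chain end, as the only ring compound shown, compound 1, carries bromo. Also open, from the compounds shown here alone, is how fluoro, methyl or a nitrile on that aromatic carbon, or a carboxylic acid or a longer chain at the sulfur-bearing end, would read in this assay.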